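Fluoro for chloro: expected growth inhibition of compound 3

The compounds below may be only part of what the source reports. "The series", "measured", "known", "first", "only" and "open" are said of these compounds alone.

Of the compounds shown here, two have been measured in a functional assay on MOLT-4 cells (Homo sapiens) for inhibition, read by sulforhodamine B assay, with a stated time of 48 h; a lower number here means a stronger inhibitor of growth, a higher number a weaker inhibitor of growth. Compound 1 `N=C(N)c1ccc(-c2ccc(-c3ccc(Cl)cc3)s2)s1` gives 1780 nM, and compound 2 `N=C(N)c1ccc(-c2ccc(-c3cncc4ccccc34)s2)s1` gives 1170 nM. Compound 1 stands at the top of the two numbers, but its gap to compound 2 lies within the scatter, so neither reads as the stronger inhibitor. Compound 3 `N=C(N)c1ccc(-c2ccc(-c3ccc(F)cc3)s2)s1` differs from compound 1 by fluoro in place of chloro on an aromatic carbon. Within the data shown here, no measured pair covers this change. In this assay the expected step is a 1.2-fold higher number from compound 1 to compound 3 (0.07 log units; within the scatter), not beyond the scatter, in either direction. Compound 3 is expected to give 2100 nM, within a range of 900 nM to 4800 nM.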

Compound 3, concentration for 50% growth inhibition: 1520 nM
For compound 3 the middle estimate is 1.4-fold (0.14 log units) above the measured one; the range from low to high includes it.
By their numbers in this assay, from the lowest: compounds 2, 3 and 1 (each within the scatter of the next).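

Fluoro in place of chloro on this aromatic carbon is the only one-place change that can be read so far, and in this assay it gives a 1.2-fold lower number from compound 1 to compound 3 (0.07 log units; within the scatter). At this position, the two halogens therefore cannot be told apart on growth inhibition. No evidence on hand bears on this result. From the compounds shown here alone, what a methoxy group, a nitrile or an amine on the same carbon would give remains open. So does the effect of any change to the shared core.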